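Swapping an Ethyl for Methylsulfanyl on a Shared Core

The source may report more compounds than this note shows. Statements on the series, on what has been measured and on what is new or still open speak of the compounds shown alone.

Of the compounds shown here, three on one shared core have been measured. Compound 1 `COCc1nc2nc(C)cc(Nc3ccc(S(F)(F)(F)(F)F)cc3)n2n1`, compound 2 `CCc1nc2nc(C)cc(Nc3ccc(C(F)(F)F)cc3)n2n1` and compound 3 `CCOc1nc2nc(C)cc(Nc3ccc(S(F)(F)(F)(F)F)cc3)n2n1` were each tested in an ADME assay on a cell-free system (plasma, Homo sapiens) for protein binding. Compound 1 gives 91.7%, compound 2 gives 87.5% and compound 3 gives 97.7%. Compound 2 and compound 1 lie within the scatter of each other, while compound 3 sits beyond it, with a smaller unbound fraction. Among the measured compounds shown here, the only clean step among measured pairs is a 3.6-fold lower unbound fraction from compound 1 to compound 3 (0.56 log units; beyond the scatter). Compound 4 `CSc1nc2nc(C)cc(Nc3ccc(C(F)(F)F)cc3)n2n1` differs from compound 2 by methylsulfanyl in place of ethyl on an aromatic carbon. For the measured compounds named here, no measured step swaps these two groups, so the expectation is for at most a small shift, likely within the scatter. Compound 4 is expected to give 90%, between 82% and 95%. This estimate means a 1.3-fold lower unbound fraction from compound 2 to compound 4 (0.10 log units; within the scatter).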

Compound 4, plasma protein binding: 91.8%
Compound 4: middle estimate off by 1.2-fold (0.09 log units) (unbound fraction), on the high side; the range from low to high includes it.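

In this assay, methylsulfanyl in place of ethyl on this aromatic carbon between two ring nitrogen atoms gives a 1.5-fold lower unbound fraction from compound 2 to compound 4 (0.18 log units; within the scatter), so no real shift can be read from this swap. Sulfur and a hydrogen-bond acceptor thus enter here with no change beyond the scatter. Nothing measured here bears on the reason for this result.

On these data alone, whether an amine, a carboxylic acid or a longer chain on this carbon would move binding stays open. So does whether ethoxy, which brought a 3.6-fold lower unbound fraction from compound 1 to compound 3 (0.56 log units; beyond the scatter), would act alike on the core of compound 2.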